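Amide swap from compound 2: solubility working notes

The source may report more compounds than this note shows. Statements on the series, on what has been measured and on what is new or still open speak of the compounds shown alone.

Measured values in (a physicochemical assay for solubility, with a stated time of 24 h, at pH 2.2; on this read-out higher numbers stand for higher solubility and lower numbers for lower solubility) so far:
- compound 1 (`O=C(NCc1cccnc1)c1ccc2ccc(C(=O)c3ccccc3)c-2cc1`) gives (70 ug/mL)
- compound 2 (`COC(=O)c1ccc2c(C(=O)Nc3ccccc3)cn(C)c2c1`) gives a limit (< 1 ug/mL)
- compound 3 (`c1cc2ccc(CN3CCCCC3)ccc-2c1`) gives a limit (> 56 ug/mL)

Compound 2 stands at a limit of the assay and not at a number (< 1 ug/mL). Compound 3 also gives only a limit (> 56 ug/mL). Compound 1 alone has a numeric value (70 ug/mL), and its core differs from that of compound 2.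

Compound 4 (`COC(=O)c1ccc2c(C(=O)N(C)C)cn(C)c2c1`) keeps the core of compound 2 and carries dimethylamino in place of anilino on a carbonyl carbon. Among the measured compounds shown here, no measured pair in this set shows this change, so the expectation is uncertain. A rise beyond the scatter is expected in (this assay), starting from the limit of compound 2 (< 1 ug/mL). The expected step is a rise (an at least 40-fold higher number from compound 2 to compound 4 (1.60 log units; beyond the scatter)). The estimate for compound 4 is (40 ug/mL). The expected range for compound 4 runs from (8 ug/mL) to (200 ug/mL).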

Compound 4, solubility: 50 ug/mL
The estimate for compound 4 lay 1.3-fold (0.10 log units) below the measured number; the range from low to high includes it.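

In this assay, the position on the carbonyl carbon of the shared core now has its first measured change: dimethylamino in place of anilino gives an at least 50-fold higher number from compound 2 to compound 4 (1.69 log units; beyond the scatter). Compound 2 stands at a limit of the assay and not at a number, so this step gives only a lower bound on the size of the change: the limit of < 1 ug/mL in this assay, at which 1 of the 4 values shown sits. Among the compounds shown here, compound 1 and compound 3 have other cores and could not show this change, which makes this pair the only direct reading for the position.

For the compounds shown here, the change removes the six-membered aromatic ring and the hydrogen-bond donor of anilino together, and the single pair cannot separate the two. Also open, from the compounds shown here alone, is whether morpholino or N-methylanilino on this carbonyl carbon would stand with compound 4 or with compound 2 in this assay.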